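The source may hold more compounds than are shown below. What is called first, only, known or untested is meant among the compounds shown, and "the series" means these compounds.

Measured compounds:
- compound 1 `O=C(Nc1ccc(-n2ncc3c(Cl)cccc32)cc1)Nc1ccc(Cl)c(C(F)(F)F)c1`: 4600 nM
- compound 2 `O=C(Nc1ccc(-n2ncc3c(F)cccc32)cc1)Nc1ccc(Cl)c(C(F)(F)F)c1`: 8200 nM
- compound 3 `O=C(Nc1ccc(-n2ncc3ccccc32)cc1)Nc1ccc(Cl)c(C(F)(F)F)c1`: 18200 nM

In a functional assay on HT-29 cells (Homo sapiens) for cytotoxicity, read by MTT assay, with a stated time of 72 h (on this read-out lower numbers stand for stronger inhibition and higher numbers for weaker inhibition), compound 2 stands second highest of the three numbers; its nearest neighbour is compound 1, with a 1.8-fold higher number from compound 1 to compound 2 (0.25 log units; within the scatter), and its furthest is compound 3, with a 2.2-fold higher number from compound 2 to compound 3 (0.35 log units; beyond the scatter). Compound 4 `CNc1cccc2c1cnn2-c1ccc(NC(=O)Nc2ccc(Cl)c(C(F)(F)F)c2)cc1` differs from compound 2 by methylamino in place of fluoro on an aromatic carbon. Among the compounds with values here, no measured step places a methylamino group at that carbon. Within the data shown here, the steps that bear on it concern the same carbon: a 4.0-fold higher number from compound 1 to compound 3 (0.60 log units; beyond the scatter) and a 2.2-fold higher number from compound 2 to compound 3 (0.35 log units; beyond the scatter), both modest rises when the halogen is replaced by hydrogen, while a 1.8-fold higher number from compound 1 to compound 2 (0.25 log units; within the scatter) stays within the scatter. On this basis a step toward a higher number, of about the size seen on removing the halogen, is expected, with the direction uncertain. Compound 4 is estimated at 14000 nM (range 4500 nM to 40000 nM), that is an expected 1.7-fold higher number from compound 2 to compound 4 (0.23 log units; within the scatter).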

Compound 4, half-maximal inhibitory concentration: 5900 nM
Compound 4: middle estimate off by 2.4-fold (0.38 log units), on the high side; measured number inside the range.
By their numbers in this assay, from the lowest: compounds 1, 4 and 2 (each within the scatter of the next); then compound 3.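

At this carbon a halogen is not required in this assay: methylamino in place of hydrogen gives a 3.1-fold lower number from compound 3 to compound 4 (0.49 log units; beyond the scatter) and so recovers a modest step. Methylamino in place of fluoro gives a 1.4-fold lower number from compound 2 to compound 4 (0.14 log units; within the scatter) and methylamino in place of chloro gives a 1.3-fold higher number from compound 1 to compound 4 (0.11 log units; within the scatter), so both stay within the scatter and methylamino cannot be separated from either halogen here. Nothing available explains these steps.

Open, on these data alone, is whether a dimethylamino or methoxy group at this carbon would match methylamino. Also open, as far as these compounds go, is how a longer chain, such as ethylamino, would behave there.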